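The source may hold more compounds than are shown below. What is called first, only, known or untested is meant among the compounds shown, and "the series" means these compounds.

Working notes on the series.

The common core carries a three-carbon amide chain ending in a trifluoromethyl-substituted phenyl; the variation lies on the aromatic carbon of the ring that holds the nitrogen. In an assay on isolated protein for displacement of a labelled ligand from melanin-concentrating hormone receptor 1 (Homo sapiens) (a lower number here means a stronger inhibitor, a higher number a weaker inhibitor), compound 1 `CC1CCN(c2ccc3cc(NC(=O)CCc4ccc(C(F)(F)F)cc4)ccc3n2)C1` gives 2 nM, and compound 2 `O=C(CCc1ccc(C(F)(F)F)cc1)Nc1ccc2nc(N3CCCC3)ccc2c1` gives 3 nM; 3 nM (2 entries). Compound 3 `Nc1ccc2cc(NC(=O)CCc3ccc(C(F)(F)F)cc3)ccc2n1`, which carries a bare amino group there, gives 240 nM and so stands highest of the numbers measured; the change from compound 1 to compound 3 was a 120-fold higher number from compound 1 to compound 3 (2.08 log units; beyond the scatter).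

Compound 4 `CNC(=O)NC1CCN(c2ccc3cc(NC(=O)CCc4ccc(C(F)(F)F)cc4)ccc3n2)C1` is not yet measured. Relative to compound 3 it carries 3-((methylcarbamoyl)amino)pyrrolidin-1-yl in place of amino on an aromatic carbon. Going by the values given here, this runs the one measured step backwards: a ring-bearing amine returns in place of the amino group, the same kind of swap that from compound 1 to compound 3 cost a 120-fold higher number from compound 1 to compound 3 (2.08 log units; beyond the scatter). Compound 2, with an unsubstituted pyrrolidin-1-yl, sits close to compound 1, so the added methylcarbamoylamino group is the open question. A large drop is expected, estimated as a 30-fold lower number from compound 3 to compound 4 (1.48 log units; beyond the scatter). The value of compound 4 in this assay is therefore expected to be 8 nM, likely between 2 nM and 40 nM.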

Compound 4, half-maximal inhibitory concentration: 6 nM
Compound 4: middle estimate off by 1.3-fold (0.12 log units), on the high side; measured number inside the range.
By their numbers in this assay, from the lowest: compound 1; then compound 4; then compound 3.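

Going by these compounds alone, compound 3 showed only that a bare amino group on this aromatic carbon gives a much weaker number than compound 1. In this assay the position recovers with the much larger 3-((methylcarbamoyl)amino)pyrrolidin-1-yl group, a step of a 40-fold lower number from compound 3 to compound 4 (1.60 log units; beyond the scatter), so the loss seen with the amino group is not a fixed feature of the shared core. The saturated ring also accepts (methylcarbamoyl)amino in place of methyl at a limited cost, a 3.0-fold higher number from compound 1 to compound 4 (0.48 log units; beyond the scatter), which is modest but still a real difference. No measured evidence bears on what lies behind either step. The compounds shown leave open how an open-chain dimethylamino group would read on the aromatic carbon. They also leave open whether a hydroxyl or a carboxylic acid on the saturated ring carbon would stay as close to compound 1.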